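This account rests on a few compounds, and the source may have more. Where it says the series, first, only, none or still open, it means among the compounds named here.

Working notes on the series, read in an assay on HEK293 cells for displacement of a labelled ligand from Type-2 angiotensin II receptor (Homo sapiens), tested at 10 uM; on this read-out higher numbers stand for a stronger effect at the one concentration tested and lower numbers for a weaker effect. Going by the values given here, compound 2 `CC[C@H](C)[C@H](NC(=O)c1cccc(Cn2ccnc2)c1)C(=O)NNS(=O)(=O)c1ccccc1` gives 18% in this assay and stands highest of the two numbers measured so far; its nearest neighbour is compound 1 `CCCCNC(=O)[C@@H](NC(=O)c1cccc(Cn2ccnc2)c1)[C@@H](C)CC`, which gives 3%, the gap lying beyond the scatter. Compound 3 `CC[C@H](C)[C@H](NC(=O)c1cccc(Cn2ccnc2)c1)C(N)=O` has not yet been measured. It differs from compound 2 by hydrogen in place of (phenylsulfonyl)amino on an amide-type nitrogen. Among the compounds with values here, the one measured step that bears on this change is a number 15 percentage points higher from compound 1 to compound 2 (beyond the scatter), in which (phenylsulfonyl)amino entered in place of butyl on the amide-type nitrogen and the number rose modestly. Compound 3 takes that same group off again and leaves only hydrogen on the amide-type nitrogen, so the gain seen in that step is expected to be given back; a downward step beyond the scatter is expected, the open question being whether hydrogen lands near the level of butyl or somewhat lower. Compound 3 is therefore estimated at 5%, with a range from -5% to 15%, the expected step being a number 13 percentage points lower from compound 2 to compound 3 (beyond the scatter).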

Compound 3, a percentage reported as inhibition, at one concentration (the size of the read-out at that concentration, not a potency): "not active" (no number reported)
Compound 3: no number reported; the estimate stays without a comparison.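

Going by these compounds alone, compound 3 is reported as not active with no number, so no step from compound 2 to compound 3 can be read. The compounds shown leave open how hydrogen on the amide-type nitrogen compares in size of effect with (phenylsulfonyl)amino or butyl there. No supporting evidence bears on this result.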